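Methoxy for Methyl on the Aryl Ring of Compound 3

This account rests on a few compounds, and the source may have more. Where it says the series, first, only, none or still open, it means among the compounds named here.

Measured compounds:
Compound 1, `COc1ccccc1N1C(=O)C(C)SC1c1cccc(C(=O)NCCCCc2ccccc2)c1`, gives 95% in a functional assay on HOS-TE85 cells (Homo sapiens) for inhibition, read by CCK-8 assay, with a stated time of 72 h, tested at 1 uM; a lower number here means less inhibition, a higher number more inhibition at the concentration tested (going by the name of the read-out).
Compound 2, `COc1ccccc1N1C(=O)CSC1c1cc(F)cc(C(=O)O)c1`, gives 0% in this assay.
Compound 3, `COc1ccc(C)cc1N1C(=O)CSC1c1cccc(C(=O)NCCCCc2ccccc2)c1`, gives 95% in this assay.

Compound 3 stands level with compound 1 at the digits shown, and the two together give the highest numbers of the three. Compound 2, which carries a carboxylic acid where compounds 1 and 3 carry an amide, lies far lower, by a gap well beyond the scatter. Between compounds 1 and 3 the aryl ring on the shared core carries a hydrogen in one and a methyl in the other, and the two values do not differ at the digits shown.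

Compound 4, `COc1ccc(OC)c(N2C(=O)CSC2c2cccc(C(=O)NCCCCc3ccccc3)c2)c1`, has not yet been measured. Its change from compound 3 is methoxy in place of methyl on an aromatic carbon. For the measured compounds named here, since compound 1 and compound 3 both give 95% despite differing at this same ring, that ring appears to bear variation without loss at the concentration tested, though only two such compounds support this. The step from compound 3 to compound 4 in this assay is therefore expected to be small, a number 5 percentage points lower from compound 3 to compound 4 (within the scatter), none beyond the scatter. Compound 4 is estimated to give 90%, between 70% and 99%.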

Compound 4, a percentage reported as inhibition, at one concentration (the size of the read-out at that concentration, not a potency): 20%
Beside the measured number, compound 4's estimate is 70 percentage points above it; measured number below the stated range.
By their numbers in this assay, from the lowest: compound 2; then compound 4; then compounds 1 and 3 (each within the scatter of the next).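

In this assay the change from 2-methoxy-5-methylphenyl to 2,5-dimethoxyphenyl gives a number 75 percentage points lower from compound 3 to compound 4 (beyond the scatter) on this single replacement of methyl by methoxy. For the compounds shown here, the number in this assay is therefore far lower after this change on the aromatic carbon meta to a large group and para to a methoxy group than the opening comparison suggested, and this matched pair is the only direct reading of a change at this position. Methoxy differs from methyl here by an added oxygen and a hydrogen-bond acceptor, but nothing in the data shows which feature of the new group accounts for the drop.

The compounds shown leave open whether an ethyl group, a chlorine atom or a hydroxyl group on this carbon would stay with compound 3 or fall with compound 4, and so whether the loss follows the oxygen or the longer substituent. They also leave open how far the two compounds are separated in potency, since each reading comes from a single concentration.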